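Pyrazolyl in Place of Chloro on the Chalcone Aryl

The source may hold more compounds than are shown below. What is called first, only, known or untested is meant among the compounds shown, and "the series" means these compounds.

Compound 1 `Cc1cc(Nc2ccc(C(=O)/C=C/c3ccccc3F)cc2)n2nc(SCc3nc4ccccc4[nH]3)nc2n1` — 250 nM in a functional assay on SW-620 cells (Homo sapiens) for cytotoxicity, read by MTT assay, with stated times of 4 h and 72 h, tested at 2 uM; a higher number here means a weaker inhibitor, a lower number a stronger inhibitor
Compound 2 `Cc1cc(Nc2ccc(C(=O)/C=C/c3ccc4ccccc4c3)cc2)n2nc(SCc3nc4ccccc4[nH]3)nc2n1` — 5 nM
Compound 3 `Cc1cc(Nc2ccc(C(=O)/C=C/c3ccc(Cl)cc3)cc2)n2nc(SCc3nc4ccccc4[nH]3)nc2n1` — 230 nM

Among the three measured compounds, compound 3 gives the second highest number in this assay. The nearest step is a 1.1-fold lower number from compound 1 to compound 3 (0.04 log units; within the scatter), so the two are not distinguishable; the furthest is a 46-fold higher number from compound 2 to compound 3 (1.66 log units; beyond the scatter).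

Compound 4 `Cc1cc(Nc2ccc(C(=O)/C=C/c3ccc(-n4cccn4)cc3)cc2)n2nc(SCc3nc4ccccc4[nH]3)nc2n1` has not yet been measured. It differs from compound 3 in one place: 1H-pyrazol-1-yl in place of chloro on an aromatic carbon. The bearing steps are those that swap the aryl group on the chain: a 50-fold lower number from compound 1 to compound 2 (1.70 log units; beyond the scatter) and a 46-fold higher number from compound 2 to compound 3 (1.66 log units; beyond the scatter), both large, whereas a 1.1-fold lower number from compound 1 to compound 3 (0.04 log units; within the scatter) was within the scatter. For the measured compounds named here, no measured step adds a second ring to the phenyl in this position, so the expectation is uncertain. The change in compound 4 is expected to bring a modest lower number, a 2.3-fold lower number from compound 3 to compound 4 (0.36 log units; beyond the scatter), smaller than the step to compound 2. Compound 4 is therefore estimated at 100 nM, in the range 20 nM to 500 nM.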

Compound 4, half-maximal inhibitory concentration: 340 nM
The estimate for compound 4 lay 3.4-fold (0.53 log units) below the measured number; the measured number falls inside the stated range.
By their numbers in this assay, from the lowest: compound 2; then compounds 3, 1 and 4 (each within the scatter of the next).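

In this assay, 1H-pyrazol-1-yl in place of chloro gives a 1.5-fold higher number from compound 3 to compound 4 (0.17 log units; within the scatter), so a five-membered aromatic ring at this aromatic carbon does not separate compound 4 from compound 3. The comparison with the 2-fluorophenyl group gives a 1.4-fold higher number from compound 1 to compound 4 (0.13 log units; within the scatter), again without a separation, whereas a 68-fold higher number from compound 2 to compound 4 (1.83 log units; beyond the scatter) shows that a second ring on the aryl group is not in itself enough to match compound 2. Among the four compounds, only the naphthalen-2-yl group stands apart from the rest. Nothing shown here gives a measured reason for that gap.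

The compounds shown leave open whether any other two-ring aryl group, such as naphthalen-1-yl or quinolin-6-yl, would come close to compound 2. They also leave open what an amine or a carboxylic acid would give on this aromatic carbon.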